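A few compounds are considered here, and "the series" means these few. Any claim that something is new, unique, unknown or untested is made for them only; others in the source may bear on it.

Measured so far in a functional assay on MCF7 cells (Homo sapiens) for inhibition, read by fluorescence, with a stated time of 72 h; on this read-out higher numbers stand for weaker inhibition of growth and lower numbers for stronger inhibition of growth:
- Compound 1 `CCCCCCn1cnc2c(Nc3ccc(Cl)cc3)nc(N[C@H]3CC[C@H](N)CC3)nc21`: 4200 nM
- Compound 2 `CCCCn1cnc2c(NCc3cccc(Cl)c3)nc(N[C@H]3CC[C@H](N)CC3)nc21`: 2200 nM
- Compound 3 `CC(C)CCn1cnc2c(NCc3cccc(Cl)c3)nc(N[C@H]3CC[C@H](N)CC3)nc21`: 4700 nM

Compound 2, at 2200 nM, sits at the low end of this small set, although compound 1 lies within the usual scatter of it. The next compound, compound 4 `CCCCn1cnc2c(Nc3cccc(Cl)c3)nc(N[C@H]3CC[C@H](N)CC3)nc21`, keeps everything in compound 2 except one group: 3-chlorophenyl in place of 3-chlorobenzyl on a nitrogen on an aromatic ring.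

Within the data shown here, no measured step makes this exact change. Among the measured compounds shown here, the only step available is a 2.1-fold higher number from compound 2 to compound 3 (0.33 log units; beyond the scatter), and it lies elsewhere in the molecule, on the saturated chain. It therefore shows only how large a single small edit has been in this series: modest, and just beyond the scatter.

The closest hint comes from compound 1, at 4200 nM, which also has a chlorophenyl group on that nitrogen. However, it differs from compound 4 in its chain and in where the chlorine sits, so the hint is weak. Neither comparison points to a large shift in this assay, and a small rise at most seems likely.

The expected change is a 1.4-fold higher number from compound 2 to compound 4 (0.13 log units; within the scatter), which would be no step beyond the scatter. For compound 4 the estimated value is 3000 nM, with an expected range from 1000 nM to 9000 nM.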

Compound 4, concentration for 50% growth inhibition: 2000 nM
Estimate against measurement, compound 4: 1.5-fold (0.18 log units) above; the measured number falls inside the stated range.
By their numbers in this assay, from the lowest: compounds 4, 2, 1 and 3 (each within the scatter of the next, the first and the last beyond it).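

In this assay, among these compounds, this is the first measured edit at the nitrogen on the aromatic ring: 3-chlorophenyl in place of 3-chlorobenzyl gives a 1.1-fold lower number from compound 2 to compound 4 (0.04 log units; within the scatter). Among the compounds shown here, the group goes from 8 heavy atoms to 7, and the printed step lies within the scatter, so compound 2 and compound 4 cannot be told apart in this assay, whereas the only earlier single-place step, on the saturated chain, was a 2.1-fold higher number from compound 2 to compound 3 (0.33 log units; beyond the scatter). Nothing measured here explains why the swap of these two groups leaves the numbers within the scatter of each other.

Going by these compounds, it remains open whether a longer link on that nitrogen, such as 2-(3-chlorophenyl)ethyl, or fluorine in place of the chlorine would also stay within the scatter of compound 2. It is also unknown whether the same swap would behave alike on the branched chain of compound 3, and compound 1 cannot settle this, since it differs from compound 4 in both its hexyl chain and the place of its chlorine.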